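Swapping the ester-bearing amide arm of a weak cholesterol-transporter ligand

The compounds below may be only part of what the source reports. "The series", "measured", "known", "first", "only" and "open" are said of these compounds alone.

Measured compounds:
compound 1, `COC(=O)CCNC(=O)CN1CN(c2ccccc2)C2(CCN(C(=O)c3ccc(C4CCCCC4)cc3)CC2)C1=O`, 12900 nM
compound 2, `COC(=O)CCNC(=O)CN1CN(c2ccccc2)C2(CCN(C(=O)c3ccc(C(C)(C)C)cc3)CC2)C1=O`, "not determined" (no result reported)

The series rests on a shared spiro core carrying a cyclohexyl-substituted or tert-butyl-substituted benzoyl group. Only compound 1 has a number: in an assay on HEK293 cells for displacement of a labelled ligand from NPC1-like intracellular cholesterol transporter 1 (Homo sapiens) (a lower number here means a stronger inhibitor, a higher number a weaker inhibitor), compound 1 gives 12900 nM, which marks it as a weak inhibitor. Compound 2, with the tert-butyl group in place of cyclohexyl, gives "not determined" (no result reported) in this assay, so nothing can be said of how the two compare.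

Compound 3, `CS(=O)(=O)N1CCN(C(=O)CN2CN(c3ccccc3)C3(CCN(C(=O)c4ccc(C5CCCCC5)cc4)CC3)C2=O)CC1`, keeps the cyclohexyl-substituted benzoyl group and differs from compound 1 only at the amide terminus: 4-(methylsulfonyl)piperazin-1-yl in place of (2-(methoxycarbonyl)ethyl)amino on a carbonyl carbon. The change sits on a carbonyl carbon whose other neighbours are a saturated chain carbon, so the core and the benzoyl side are untouched.

Among the measured compounds shown here, no measured pair in the set shows what this kind of exchange does in this assay. For the measured compounds named here, with a single reference value and no precedent, the step from compound 1 to compound 3 is expected to stay within the scatter, a 1.2-fold lower number from compound 1 to compound 3 (0.07 log units; within the scatter), and compound 3 is estimated at 11000 nM, between 3500 nM and 35000 nM.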

Compound 3, half-maximal inhibitory concentration: 6300 nM
Compound 3: the middle estimate sits 1.7-fold (0.24 log units) above what was measured, and the stated range covers the measured number.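

In this assay, placing 4-(methylsulfonyl)piperazin-1-yl on the carbonyl carbon in place of (2-(methoxycarbonyl)ethyl)amino gives a 2.0-fold lower number from compound 1 to compound 3 (0.31 log units; beyond the scatter), a modest step but the first comparison the series offers. It shows that this position accepts a six-membered non-aromatic ring with 2 hetero atoms in place of an open chain, and that neither the methyl ester nor the hydrogen-bond donor of that chain is needed to hold the number at the level of compound 1, with the core and the cyclohexyl-substituted benzoyl group unchanged. Nothing in the data explains the step, and the exchange alters several features at once, so the result cannot be assigned to any one of them.

As far as these compounds go, whether the gain belongs to the ring or to the methylsulfonyl group stays open, and a morpholine or an unsubstituted piperidine at this carbonyl carbon, or a carboxylic acid at the end of the original chain, would begin to separate these parts. From the compounds shown here alone, whether the same exchange carries over to the tert-butyl-substituted benzoyl group also stays open, as compound 2 has no reported result to compare with.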